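The source may hold more compounds than are shown below. What is called first, only, known or untested is meant among the compounds shown, and "the series" means these compounds.

Of the compounds shown here, three have been measured so far in a functional assay on PC-3 cells (Homo sapiens); a higher number here means a weaker inhibitor of growth, a lower number a stronger inhibitor of growth. Compound 1 (`O=S(=O)(/C=C/c1ccc(Cl)cc1)Cc1ccc(Nc2ncnc3ccc(Br)cc23)cc1`) reads 2000 nM there, compound 2 (`O=S(=O)(/C=C/c1ccc(F)cc1Cl)Cc1ccc(Nc2ncnc3cc(Cl)ccc23)cc1`) reads 73000 nM there, and compound 3 (`COc1cc2ncnc(Nc3ccc(CS(=O)(=O)/C=C/c4ccc(Cl)cc4Cl)cc3)c2cc1OC`) reads 5000 nM on the same scale. Compound 3 therefore holds the second highest number of the three. The number of compound 1 lies lower and that of compound 2 lies higher, both gaps beyond the scatter, and the gap to compound 1 is the smaller. No pair among these three differs in only one place, so no measured single-change step is available as a guide.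

Compound 4 (`COc1cc2ncnc(Nc3ccc(CS(=O)(=O)/C=C/c4ccc(F)cc4)cc3)c2cc1OC`) departs from compound 3 in one group: 4-fluorophenyl in place of 2,4-dichlorophenyl on a double-bonded chain carbon bound to a double-bonded chain carbon describes the exchange, 4-fluorophenyl in place of 2,4-dichlorophenyl on a double-bonded chain carbon bound to a double-bonded chain carbon. The expectation starts from compound 3 at 5000 nM and, with nothing measured on this change, no step beyond the scatter is expected in this assay for it. An estimated 1.2-fold higher number from compound 3 to compound 4 (0.08 log units; within the scatter) is all that is foreseen, with only a slight lean toward a higher number. Compound 4 is estimated at 6000 nM with an expected range from 1500 nM to 25000 nM as the likely spread.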

Compound 4, concentration for 50% growth inhibition: > 100000 nM
Compound 4: a limit, no number; the forecaster's own chance of this, stated with the estimate: 5%; middle value at least 16-fold (1.22 log units) away from the limit.
By their numbers in this assay, from the lowest: compound 1; then compound 3; then compound 2. At a limit, above all of these: compound 4.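

In this assay, for the compounds shown here, the exchange of 2,4-dichlorophenyl for 4-fluorophenyl on a double-bonded chain carbon bound to a double-bonded chain carbon gives the first reading of a change in one place, and that reading is an at least 20-fold higher number from compound 3 to compound 4 (1.30 log units; beyond the scatter). Compound 4 stands at a limit of the assay, not at a number: the limit of > 100000 nM in this assay, at which 1 of the 4 values shown sits. The earlier compounds shown here, no two of which differ in only one place, could not show what this step shows: the group at this position matters in this assay, since the rest of the structure is the same in compound 3 and compound 4.

This one step cannot separate the leaving of the two chlorine atoms from the entry of the fluorine atom, and a plain phenyl or a 4-methoxyphenyl group at the same place would be needed to begin telling these apart. On these data alone, it also remains open whether the same exchange would carry the same weight on the core of compound 1 or the core of compound 2.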